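The source may hold more compounds than are shown below. What is called first, only, known or untested is meant among the compounds shown, and "the series" means these compounds.

For the measured compounds named here, compound 2 `CC(C)(C)N(NC(=O)c1ccc(F)cc1)C(=O)c1ccccc1Cl` is one of two compounds so far tested in an assay on cells for agonist activity at ecdysone receptor (Bombyx mori), read by a luciferase reporter, with a stated time of 24 h; on this read-out higher numbers stand for an effect only at larger amounts of compound and lower numbers for an effect already at smaller amounts. In this assay compound 2 gives 389 nM. Going by the values given here, the only other number belongs to compound 1 `CC(C)(C)N(NC(=O)c1ccccc1Br)C(=O)c1ccccc1Cl`, which gives 316 nM in this assay; the step of a 1.2-fold higher number from compound 1 to compound 2 (0.09 log units; within the scatter) lies within the scatter, so the two stand level. Compound 3 `CC(C)(C)N(NC(=O)c1ccc(I)cc1)C(=O)c1ccccc1Cl` is not yet measured. It differs from compound 2 in one place: iodo in place of fluoro on an aromatic carbon, on a six-membered aromatic ring of carbon only, para to a large group. Among the compounds with values here, no measured step exchanges one halogen for another at this place. Within the data shown here, the one step available, a 1.2-fold higher number from compound 1 to compound 2 (0.09 log units; within the scatter), trades a 2-bromophenyl for a 4-fluorophenyl without moving the number beyond the scatter, which gives no hint of a large shift. A step of similar weight is expected here, a 1.3-fold lower number from compound 2 to compound 3 (0.11 log units; within the scatter). Compound 3 is therefore estimated at 300 nM, within a range from 100 nM to 1000 nM.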

Compound 3, half-maximal effective concentration: 7.59 nM
Compound 3: the middle estimate sits 40-fold (1.60 log units) above what was measured; the measured number lies below the stated range.
By their numbers in this assay, from the lowest: compound 3; then compounds 1 and 2 (each within the scatter of the next).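

For the compounds shown here, at this place, para to a large group on the six-membered aromatic ring, one halogen cannot simply stand in for another: iodo in place of fluoro brings a large drop in the number in this assay (a 51-fold lower number from compound 2 to compound 3 (1.71 log units; beyond the scatter)), so compound 3 acts at much smaller amounts, even though only one heavy atom changes and no hydrogen-bond donor or acceptor is involved. The earlier step stayed within the scatter and gave no sign of such sensitivity, whereas the exchange of 2-bromophenyl for 4-iodophenyl is also large (a 42-fold lower number from compound 1 to compound 3 (1.62 log units; beyond the scatter)). Nothing available here accounts for the size of this change.

The compounds shown leave open whether a chloro, bromo or methoxy group at this place would give a number close to that of compound 3 or to that of compound 2. Also open, on these data alone, is whether iodo would have a similar effect at another place on the ring.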